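Swapping 4-methylphenyl for thiophen-2-yl on the shared core

A few compounds are considered here, and "the series" means these few. Any claim that something is new, unique, unknown or untested is made for them only; others in the source may bear on it.

compound 1 `COc1cc(C(=O)c2sc(-c3ccc(I)cc3)cc2N)cc(OC)c1OC` at 190 nM
compound 2 `COc1cc(C(=O)c2sc(-c3ccc(C)cc3)cc2N)cc(OC)c1OC` at 16 nM

In a functional assay on MOLT-4 cells (Homo sapiens) for antiproliferative activity (on this read-out higher numbers stand for weaker inhibition and lower numbers for stronger inhibition), compound 2 stands lowest of the two at 16 nM and so shows the stronger inhibition. Compound 3 `COc1cc(C(=O)c2sc(-c3cccs3)cc2N)cc(OC)c1OC` differs from it by thiophen-2-yl in place of 4-methylphenyl on an aromatic carbon. Among the compounds with values here, the one measured step on this aryl group is large, with a 12-fold lower number from compound 1 to compound 2 (1.07 log units; beyond the scatter) for methyl in place of iodo. Within the data shown here, a change here can therefore be sizeable, yet no measured step exchanges the whole ring. A moderate move to a higher number is expected, with a 3.8-fold higher number from compound 2 to compound 3 (0.57 log units; beyond the scatter) as the estimate. The estimate for compound 3 is 60 nM (expected range 15 nM to 300 nM).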

Compound 3, half-maximal inhibitory concentration: 8.9 nM
Beside the measured number, compound 3's estimate is 6.7-fold (0.83 log units) above it; the measured number lies below the stated range.
By their numbers in this assay, from the lowest: compounds 3 and 2 (each within the scatter of the next); then compound 1.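

In this assay, exchanging the whole ring gives a 1.8-fold lower number from compound 2 to compound 3 (0.25 log units; within the scatter), so at this position thiophen-2-yl, a five-membered aromatic ring, stays within the scatter of 4-methylphenyl. Set against the iodo-bearing ring, the same exchange gives a 21-fold lower number from compound 1 to compound 3 (1.33 log units; beyond the scatter), which leaves compound 1 alone at the high end of the three. Nothing available explains either step.

The compounds shown leave open whether another five-membered ring, such as furan-2-yl or thiophen-3-yl, would fall in the same range. They also leave open how a pyridine ring would behave at this position.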